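This account rests on a few compounds, and the source may have more. Where it says the series, first, only, none or still open, it means among the compounds named here.

Among the measured compounds shown here, compound 2 `COc1cc(-c2nnc3n2NC(c2ccco2)C(C(=O)c2ccc(C)cc2)S3)cc(OC)c1OC` gives the lowest number in a functional assay on HepG2 cells (Homo sapiens) for cytotoxicity, read by MTT assay, with a stated time of 48 h (a higher number here means a weaker inhibitor, a lower number a stronger inhibitor), of the two compounds measured so far, at 17400 nM. For the measured compounds named here, its nearest neighbour, compound 1 `COc1cc(-c2nnc3n2NC(c2ccco2)C(C(=O)c2ccccc2C)S3)cc(OC)c1OC`, gives 63000 nM in this assay, and the only measured step, a 3.6-fold lower number from compound 1 to compound 2 (0.56 log units; beyond the scatter), moves a methyl around the benzoyl ring rather than changing the group itself. Compound 3 `COc1cc(-c2nnc3n2NC(c2ccco2)C(C(=O)c2ccc(C(F)(F)F)cc2)S3)cc(OC)c1OC` differs from compound 2 by trifluoromethyl in place of methyl on an aromatic carbon. Going by the values given here, no measured step tests a methyl exchanged for trifluoromethyl, so no change beyond the scatter is expected, and the estimated step is a 1.1-fold lower number from compound 2 to compound 3 (0.04 log units; within the scatter). Compound 3 is therefore expected to give about 16000 nM in this assay, within a range of 5000 nM to 50000 nM.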

Compound 3, half-maximal inhibitory concentration: > 100000 nM
Compound 3: no number, only a limit; the forecaster's own chance of this, stated with the estimate: 10%; at least 6.2-fold (0.79 log units) between middle value and limit.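

Until now only a methyl had moved around the benzoyl ring; here the group itself changes on the same aromatic carbon, and the result is clearly weaker, an at least 5.7-fold higher number from compound 2 to compound 3 (0.75 log units; beyond the scatter). The other comparison, an at least 1.5-fold higher number from compound 1 to compound 3 (0.20 log units; that floor lies within the scatter), sets no order between those two compounds. Both steps rest on a limit and not on a number: the limit of > 100000 nM in this assay, at which 1 of the 3 values shown sits.

Still open, on these data alone, is whether another group on this carbon, such as chlorine, hydroxyl or an amine, would give a number lower than that of compound 2. As far as these compounds go, the size of the drop with trifluoromethyl also remains unknown.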